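The source may report more compounds than this note shows. Statements on the series, on what has been measured and on what is new or still open speak of the compounds shown alone.

Measured so far:
compound 1, `CCn1c(SCC(=O)c2ccccc2)nnc1-c1cc(OC)c(OC)c(OC)c1`, 29%
compound 2, `COc1cc(-c2nnc(SC/C(=N/O)c3ccccc3)n2-c2ccccc2)cc(OC)c1OC`, 61%
compound 3, `C=CCn1c(SCC(=O)c2ccccc2)nnc1-c1cc(OC)c(OC)c(OC)c1`, 49%

All three were tested in a functional assay on the whole organism (strain albino) for inhibition, with Rattus norvegicus as the target, read by paw edema, with a stated time of 1 h, at a dose of 0.28 mmol/kg by the oral route; on this read-out higher numbers stand for more inhibition at the one dose given (going by the name of the read-out) and lower numbers for less inhibition. Compound 3 stands second of the three: compound 2 gives 61%, a higher number, while compound 1 gives 29%, a lower one, and both gaps lie beyond the scatter.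

The next compound is compound 4, `COc1cc(-c2nnc(SCC(=O)c3ccccc3)n2-c2ccccc2)cc(OC)c1OC`. It differs from compound 3 by phenyl in place of allyl on an aromatic nitrogen.

Among the compounds with values here, one measured step touches the same position: a number 20 percentage points higher from compound 1 to compound 3 (beyond the scatter). A larger group on that nitrogen went with a higher number. Compound 2 also carries a phenyl on that nitrogen, though with a different side chain, and compound 2 gives 61%. Taken together, these point to a modest rise for compound 4. The expected step is a number 9 percentage points higher from compound 3 to compound 4 (within the scatter), in the upward direction but not large. Compound 4 is therefore estimated at 58%, within a range from 45% to 70%.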

Compound 4, a percentage reported as inhibition, in the whole organism at one dose (the size of the read-out at that dose, not a potency): 44%
Compound 4: middle estimate off by 14 percentage points, on the high side; measured number below the stated range.
By their numbers in this assay, from the lowest: compound 1; then compounds 4 and 3 (each within the scatter of the next); then compound 2.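

In this assay, replacing allyl on the aromatic nitrogen with phenyl, which brings in a six-membered aromatic ring, gives a number 5 percentage points lower from compound 3 to compound 4 (within the scatter), so these two groups cannot be told apart here. Both also compare in the same way with ethyl, since the change to phenyl gives a number 15 percentage points higher from compound 1 to compound 4 (beyond the scatter), and the earlier change to allyl gave a number 20 percentage points higher from compound 1 to compound 3 (beyond the scatter). With phenyl held on that nitrogen, the side chain still matters: the change on the saturated chain carbon bound to a sulfur, from the oxime of compound 2 to the carbonyl of compound 4, gives a number 17 percentage points lower from compound 2 to compound 4 (beyond the scatter).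

No available evidence explains these shifts. Still open, going by these compounds, is how a benzyl group or a butyl chain on that nitrogen would read, and whether the oxime side chain would give a similar number with ethyl or allyl there.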